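The source may hold more compounds than are shown below. What is called first, only, known or untested is meant among the compounds shown, and "the series" means these compounds.

Compound 1 `CCSc1nnc(-c2ccccc2)n1C`: > 200 mg/kg
Compound 2 `CC[S+]([O-])c1nnc(-c2ccccc2)n1C`: > 200 mg/kg

Both compounds were tested in a functional assay on the whole organism for antagonist activity, with Mus musculus as the target, in the maximal electroshock model; on this read-out higher numbers stand for an effect only at larger amounts of compound and lower numbers for an effect already at smaller amounts. Compound 1 gives > 200 mg/kg, which is a limit of the assay and not a number. Compound 2 gives > 200 mg/kg, which is also a limit. Compound 2 therefore has no exact position on the scale, and the record so far is the limit of > 200 mg/kg in this assay, at which 2 of the 2 values shown sit.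

The next compound is compound 3 `CCS(=O)(=O)c1nnc(-c2ccccc2)n1C`, in which ethylsulfonyl takes the place of the group carried by compound 2. The change is a group of 5 heavy atoms (2 carbon, 2 oxygen, 1 sulfur; no ring) in place of a group of 4 heavy atoms (2 carbon, 1 oxygen, 1 sulfur; no ring), on an aromatic carbon. It sits on an aromatic carbon of a five-membered aromatic ring with 3 nitrogen.

For the measured compounds named here, only one measured step bears on this change, and it is a step that the two limits leave unreadable from compound 1 to compound 2. That step offers no size to carry forward, so neither a direction nor a step beyond the usual scatter can be expected with any support. The expected change is a number no higher from compound 2 to compound 3 (the limit leaves the size open), and the result may well be another limit in this assay. Compound 3 is estimated at 200 mg/kg, with an expected range from 70 mg/kg to 400 mg/kg.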

Compound 3, dose for half-maximal effect: > 200 mg/kg
Compound 3: no number, only a limit; the forecaster's own chance of this, stated with the estimate: 60%; the middle value lies on the limit itself.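

Compound 1, compound 2 and compound 3 each give only a limit of the assay and not a number in this assay, so no step among them can be read: the limit of > 200 mg/kg in this assay, at which 3 of the 3 values shown sit.

The compounds shown leave open how ethylsulfanyl, the group of compound 2 and ethylsulfonyl would rank against one another on an exact scale.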